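This account rests on a few compounds, and the source may have more. Where it says the series, first, only, none or still open, it means among the compounds named here.

Measured compounds and their values in the assay:
compound 1, `C#Cc1cccc(Nc2ncnc3cc(OC)c(OCCCN4CCNCCNCCNCC4)cc23)c1`: 28600 nM
compound 2, `COc1cc2ncnc(Nc3ccc(Br)cc3F)c2cc1OCCCN1CCNCCNCCNCC1`: 15200 nM
compound 3, `COc1cccc(Nc2ncnc3cc(OC)c(OCCCN4CCNCCNCCNCC4)cc23)c1`: recorded only as a limit of the assay, > 50000 nM

In a functional assay on A549 cells (Homo sapiens) for antiproliferative activity, read by MTT assay, with a stated time of 72 h (a higher number here means a weaker inhibitor, a lower number a stronger inhibitor), compound 1 stands at the highest of the two numbers shown. The nearest measured neighbour is compound 2, with a step of a 1.9-fold lower number from compound 1 to compound 2 (0.27 log units; within the scatter). The value of compound 3 is a limit, not a number, as noted in the limit of > 50000 nM in this assay, at which 1 of the 3 values shown sits.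

Compound 4, `COc1cc2ncnc(Nc3cccc(F)c3)c2cc1OCCCN1CCNCCNCCNCC1`, has not yet been measured. It differs from compound 1 by fluoro in place of ethynyl on an aromatic carbon. The step that bears most directly is an at least 1.7-fold higher number from compound 1 to compound 3 (0.24 log units; that floor lies within the scatter), where the same ethynyl of compound 1 is also exchanged for a small group, and the number rises to the limit. The step of an at least 3.2-fold higher number from compound 2 to compound 3 (0.51 log units; beyond the scatter) points the same way. Within the shared core, losing the ethynyl has so far given only a higher number or a limit, so a modest rise is expected in this assay, with a real chance that only a limit is recorded.

For compound 4 the expected value in this assay is 40000 nM, with a range from 15000 nM to 100000 nM. That estimate means an expected step of a 1.4-fold higher number from compound 1 to compound 4 (0.15 log units; within the scatter).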

Compound 4, half-maximal inhibitory concentration: > 50000 nM
Compound 4: only a limit was reported; the forecaster's own chance of this, stated with the estimate: 35%; middle value at least 1.2-fold (0.09 log units) away from the limit.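

In this assay, within the data shown here, compound 4 is recorded only as a limit, > 50000 nM, so fluoro on this aromatic carbon, like methoxy, gives no number, and ethynyl remains the only group at this place with a measured value. Fluoro in place of ethynyl gives an at least 1.7-fold higher number from compound 1 to compound 4 (0.24 log units; that floor lies within the scatter); that floor lies within the scatter, so this step alone does not establish a real loss on removing the ethynyl, although a second small group now ends in a limit there. The comparison with the 4-bromo-2-fluorophenyl compound gives an at least 3.2-fold higher number from compound 2 to compound 4 (0.51 log units; beyond the scatter), which lies beyond the scatter and matches the step seen for the 3-methoxyphenyl compound, while the step between compound 3 and compound 4 cannot be read, as both values are limits.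

From the compounds shown here alone, the order of fluoro and methoxy at this place stays unresolved, and the limit now recurs: the limit of > 50000 nM in this assay, at which 2 of the 4 values shown sit. Whether a nitrile, a chloro or a longer alkyne at this carbon would give a measurable value, and match or pass ethynyl, remains open.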